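Cinnamic acid series: fluoro to cyano on the aryl triazole

This account rests on a few compounds, and the source may have more. Where it says the series, first, only, none or still open, it means among the compounds named here.

Compound 1 `COc1ccc(/C=C\C(=O)O)c(OCc2cn(-c3ccccc3F)nn2)c1CC=C(C)C` carries a 2-fluorophenyl on the triazole. Going by the values given here, in a functional assay on NCI-H322 cells (Homo sapiens) for cytotoxicity, read by MTT assay, with a stated time of 24 h (a higher number here means a weaker inhibitor, a lower number a stronger inhibitor), compound 1 gives 45600 nM, the only number so far. Compound 2 `COc1ccc(/C=C\C(=O)O)c(OCc2cn(-c3ccccc3C(=O)N3CCC(O)C3)nn2)c1CC=C(C)C` has the same core with an amide-bearing aryl; in this assay compound 2 gives "not determined" (no result reported), so it adds no comparison. Compound 3 `COc1ccc(/C=C\C(=O)O)c(OCc2cn(-c3ccccc3C#N)nn2)c1CC=C(C)C` is the next entry, and in this assay it is yet to be measured. Its difference from compound 1 is cyano in place of fluoro on an aromatic carbon. Among the compounds with values here, no pair with a single change has been measured, so there is no measured step to scale this change against. With only compound 1 at 45600 nM to go on, the step from compound 1 to compound 3 is expected to be small, in either direction, and not beyond the usual scatter: a 1.0-fold lower number from compound 1 to compound 3 (0.01 log units; within the scatter). For compound 3 the estimate in this assay is 45000 nM, with a range from 18000 nM to 110000 nM.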

Compound 3, half-maximal inhibitory concentration: 14400 nM
Beside the measured number, compound 3's estimate is 3.1-fold (0.49 log units) above it, and the stated range ends above it.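

Going by these compounds alone, exchanging 2-fluorophenyl for 2-cyanophenyl gives a 3.2-fold lower number from compound 1 to compound 3 (0.50 log units; beyond the scatter) in this assay, the first step that can be read. This shows that the number responds to a single exchange on an aromatic carbon ortho to a large group, and that cyano in place of fluoro moves it towards a stronger inhibitor. The data shown offer no support for any explanation of this step.

With a single readable pair, it remains open whether this direction extends beyond cyano and fluoro: the compounds shown do not tell how an amine, a methoxy group or a carboxylic acid would read on the same aromatic carbon. They also leave open whether the step would keep its size on a core changed elsewhere.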